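The source may report more compounds than this note shows. Statements on the series, on what has been measured and on what is new or still open speak of the compounds shown alone.

Three compounds share a core in which a sulfur links the imidazole to a short chain ending in a six-membered ring. In an assay on microsomes from liver for inhibition of sterol O-acyltransferase 1 (Rattus norvegicus) (on this read-out lower numbers stand for stronger inhibition and higher numbers for weaker inhibition), compound 1 `C[C@@]1(O)CC(=O)OC(CSc2nc(-c3ccc(Cl)cc3)c(-c3ccc(Cl)cc3)[nH]2)C1` gives 180 nM. In this assay compound 2 `CC1=CC(=O)OC(CSc2nc(-c3cccc(Cl)c3)c(-c3cccc(Cl)c3)[nH]2)C1` gives 440 nM, and compound 3 `O=C1CCCC(CSc2nc(-c3ccccc3)c(-c3ccccc3)[nH]2)O1` gives 740 nM. Of the three, compound 3 carries the highest number; its gap to compound 2 lies within the usual scatter, while its gap to compound 1 lies beyond it.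

Compound 4 `c1ccc(-c2nc(SCCC3OCCCO3)[nH]c2-c2ccccc2)cc1` differs from compound 3 in one place: a group of 7 heavy atoms (5 carbon, 2 oxygen; one six-membered non-aromatic ring with 2 hetero atoms) in place of a group of 7 heavy atoms (5 carbon, 2 oxygen; one six-membered non-aromatic ring with 1 hetero atom), on a saturated chain carbon bound to a sulfur. For the measured compounds named here, no measured pair shows a change of this kind, so nothing on record tells how swapping one ring of this size for another, with a second oxygen in it, moves the number. The expected step from compound 3 to compound 4 is a 1.5-fold higher number from compound 3 to compound 4 (0.17 log units; within the scatter), a drift towards a higher number that may or may not clear the scatter. Compound 4 is therefore expected to give about 1100 nM in this assay, somewhere between 350 nM and 3500 nM.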

Compound 4, half-maximal inhibitory concentration: 730 nM
Compound 4: the middle estimate sits 1.5-fold (0.18 log units) above what was measured, within the range that was stated.
By their numbers in this assay, from the lowest: compound 1; then compounds 2, 4 and 3 (each within the scatter of the next).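

In this assay, putting the ring with 2 hetero atoms in place of the ring with 1 hetero atom gives a 1.0-fold lower number from compound 3 to compound 4 (0.01 log units; within the scatter), so compound 3 and compound 4 cannot be told apart. For the compounds shown here, this is the first measured swap on this saturated chain carbon bound to a sulfur, and it shows that one pair can lose the double bond outside aromatic rings and gain a second ring oxygen with no visible shift in the number. No measurement at hand explains why the two rings read alike.

Going by these compounds, it remains open what an amine, a carboxylic acid or a longer chain would do at this place. On these data alone, whether the same ring swap reads alike on the chlorine-bearing cores of compound 1 and compound 2 also remains open.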